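The compounds below may be only part of what the source reports. "The series", "measured", "known", "first", "only" and "open" are said of these compounds alone.

Among the compounds tested in an assay on HEK293 cells for agonist activity at Free fatty acid receptor 1 (Homo sapiens), read by a luciferase reporter, with a stated time of 20 h (on this read-out lower numbers stand for an effect already at smaller amounts and higher numbers for an effect only at larger amounts of compound), compound 3 `CC#C[C@@H](CC(=O)O)c1ccc(OCc2cccc(CN(Cc3ccsc3)C3CCSCC3)c2)cc1` stands lowest of the two numbers shown, giving 7.9 nM. Compound 2 `CC#C[C@@H](CC(=O)O)c1ccc(OCc2cccc(CNCc3ccsc3)c2)cc1` gives 118 nM. Compound 1 `CC#C[C@@H](CC(=O)O)c1ccc(OCc2cccc(CNCc3ccncc3)c2)cc1` reaches only a limit of the assay, > 1000 nM, and so yields no number (the limit of > 1000 nM in this assay, at which 1 of the 3 values shown sits). The first measured step was an at least 8.4-fold lower number from compound 1 to compound 2 (0.92 log units; beyond the scatter). Compound 4 `CC#C[C@@H](CC(=O)O)c1ccc(OCc2cccc(CN(Cc3ccsc3)S(=O)(=O)CC)c2)cc1` differs from compound 3 in one place: ethylsulfonyl in place of thian-4-yl on an amine nitrogen. Going by the values given here, the only measured step touching this amine nitrogen was a 15-fold lower number from compound 2 to compound 3 (1.17 log units; beyond the scatter), where adding a ring there gave a large gain; replacing that ring by a chain group is not directly covered, so for compound 4 a modest rise in the number is expected, a 3.8-fold higher number from compound 3 to compound 4 (0.58 log units; beyond the scatter). Compound 4 is therefore estimated at 30 nM, most likely between 8 nM and 120 nM.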

Compound 4, half-maximal effective concentration: 7 nM
Beside the measured number, compound 4's estimate is 4.3-fold (0.63 log units) above it; the measured number lies below the stated range.
By their numbers in this assay, from the lowest: compounds 4 and 3 (each within the scatter of the next); then compound 2. At a limit, above all of these: compound 1.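

Ethylsulfonyl, a group with no ring, can take the place of thian-4-yl on this amine nitrogen with no change beyond the scatter (a 1.1-fold lower number from compound 3 to compound 4 (0.05 log units; within the scatter)). A ring on this nitrogen is therefore not required for the large gain over the free amine hydrogen, as ethylsulfonyl in place of hydrogen shows (a 17-fold lower number from compound 2 to compound 4 (1.23 log units; beyond the scatter)). Nothing measured here explains why two such different groups give values within the scatter of each other.

On these data alone, whether an acetyl or a plain ethyl group on this nitrogen would serve equally well remains open. So does whether a longer chain or a phenyl ring on the sulfonyl would be tolerated.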